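Methyl for methoxy on the shared core: compound 3

A few compounds are considered here, and "the series" means these few. Any claim that something is new, unique, unknown or untested is made for them only; others in the source may bear on it.

Two compounds of this series have a number in a functional assay on A549 cells (Homo sapiens) for cytotoxicity, read by MTT assay, with a stated time of 72 h; a lower number here means a stronger inhibitor, a higher number a weaker inhibitor. Compound 1 `Cc1ccc2[nH]c(-c3ccc[nH]3)c(C3CC(=O)NC3=O)c2c1` gives 20000 nM in this assay, and compound 2 `COc1ccc2[nH]c3c(c4c(c5ccnn53)C(=O)NC4=O)c2c1` gives 8000 nM. Compound 2 stands lowest of the two, with compound 1 as its nearest neighbour at a higher number beyond the usual scatter. The pair differs in more than one place, so the gap says only what the two values show.

Compound 3 `Cc1ccc2[nH]c3c(c4c(c5ccnn53)C(=O)NC4=O)c2c1` is not yet measured. Relative to compound 2 it carries methyl in place of methoxy on an aromatic carbon. Among the measured compounds shown here, no measured pair shows this exchange, so there is no step to lean on. Given the value of compound 2 at 8000 nM, the change to compound 3 is expected to stay within the usual scatter, direction unresolved. The expected value for compound 3 is 10000 nM, with a range from 4000 nM to 30000 nM. This means an expected step of a 1.3-fold higher number from compound 2 to compound 3 (0.10 log units; within the scatter).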

Compound 3, half-maximal inhibitory concentration: 8000 nM
Estimate against measurement, compound 3: 1.3-fold (0.10 log units) above; measured number inside the range.
By their numbers in this assay, from the lowest: compounds 2 and 3 (each within the scatter of the next); then compound 1.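

In this assay, among the compounds shown here, methyl in place of methoxy on an aromatic carbon gives no change at the digits printed from compound 2 to compound 3 (within the scatter) and is the first exchange that can be read at a single place. In this pair, the oxygen and the one hydrogen-bond acceptor counted for methoxy can therefore leave the shared core with no shift beyond the scatter, although one pair says nothing about other positions or other groups. No measurement at hand accounts for this result.

From the compounds shown here alone, whether an amine, a carboxylic acid or a longer chain such as ethoxy at this position would also leave the number unmoved remains open. Compound 1 differs from compound 2 in more than one place, so what separates their values cannot be assigned to any single change.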